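Imidazole in Place of Methylpiperazine on a Four-Carbon Chain

The compounds below may be only part of what the source reports. "The series", "measured", "known", "first", "only" and "open" are said of these compounds alone.

Measured compounds:
compound 1, `O=C1c2c[n+]([O-])c3ccccc3c2C(=O)c2c1c1ccccc1n2CCN1CCCC1`, 270 nM
compound 2, `CN1CCN(CCCn2c3c(c4ccccc42)C(=O)c2c[n+]([O-])c4ccccc4c2C3=O)CC1`, 560 nM
compound 3, `CN1CCN(CCCCn2c3c(c4ccccc42)C(=O)c2c[n+]([O-])c4ccccc4c2C3=O)CC1`, 10 nM

In a functional assay on HCT-116 cells (Homo sapiens) for cytotoxicity, read by MTT assay, with a stated time of 72 h (on this read-out higher numbers stand for weaker inhibition and lower numbers for stronger inhibition), compound 3 gives the lowest of the three numbers. Its nearest neighbour is compound 1, with a 27-fold lower number from compound 1 to compound 3 (1.43 log units; beyond the scatter), and its furthest is compound 2, with a 56-fold lower number from compound 2 to compound 3 (1.75 log units; beyond the scatter); both steps lie beyond the scatter, so compound 3 is the most potent of the three.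

Compound 4, `O=C1c2c[n+]([O-])c3ccccc3c2C(=O)c2c1c1ccccc1n2CCCCn1ccnc1`, keeps the four-carbon chain of compound 3 but changes its terminus: 1H-imidazol-1-yl in place of 4-methylpiperazin-1-yl on a saturated chain carbon, four bonds along the chain from an aromatic nitrogen.

Among the compounds with values here, none of the measured steps exchanges the terminal ring while holding the chain fixed. The two large steps, a 56-fold lower number from compound 2 to compound 3 (1.75 log units; beyond the scatter) and a 27-fold lower number from compound 1 to compound 3 (1.43 log units; beyond the scatter), concern the chain, which compound 4 retains unchanged. Within the data shown here, the only step that exchanges one terminal ring for another, a 2.1-fold higher number from compound 1 to compound 2 (0.32 log units; beyond the scatter), was modest and also altered the chain. The exchange in compound 4 is therefore not covered by a comparable measured step, and the expectation rests mainly on compound 3 through 10 nM, with a moderate rise allowed for the new ring.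

Compound 4 is expected to give 50 nM, within 10 nM to 300 nM, an expected step of a 5.0-fold higher number from compound 3 to compound 4 (0.70 log units; beyond the scatter).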

Compound 4, half-maximal inhibitory concentration: 240 nM
Estimate against measurement, compound 4: 4.8-fold (0.68 log units) below; measured number inside the range.
By their numbers in this assay, from the lowest: compound 3; then compounds 4 and 1 (each within the scatter of the next); then compound 2.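

In this assay, exchanging 4-methylpiperazin-1-yl for 1H-imidazol-1-yl while keeping the chain gives a 24-fold higher number from compound 3 to compound 4 (1.38 log units; beyond the scatter), so the low number of compound 3 is not carried by the chain alone and depends on the group at its end. The gain seen earlier with the longer chain also does not appear with the new ring: the comparison with the shorter pyrrolidine compound gives a 1.1-fold lower number from compound 1 to compound 4 (0.05 log units; within the scatter), and the comparison with the shorter methylpiperazine compound gives only a 2.3-fold lower number from compound 2 to compound 4 (0.37 log units; beyond the scatter), far from the large step that set compound 3 apart. No measurement here accounts for the size of this change at the end of the chain.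

The compounds shown leave open whether the low number of compound 3 is particular to 4-methylpiperazin-1-yl or would also be reached with pyrrolidin-1-yl, piperidin-1-yl or morpholin-4-yl on the same chain. They also leave open how 1H-imidazol-1-yl behaves on a shorter or a longer chain, which would show whether chain length matters at all with this ring.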